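Aryl amide variation on the shared core

The source may report more compounds than this note shows. Statements on the series, on what has been measured and on what is new or still open speak of the compounds shown alone.

In an ADME assay on SW480 cells (Homo sapiens) for cytotoxicity, read by MTT assay, with a stated time of 72 h (a lower number here means a stronger inhibitor, a higher number a weaker inhibitor), compound 1 `Cc1ccc(N2C(=O)C/C(=C\c3cccc(C(=O)Nc4cccc(F)c4)c3)C2=O)cc1` gives 96900 nM. Compound 2 `O=C(Nc1ccc(OC(F)F)cc1)c1cccc(/C=C2\CC(=O)N(c3ccccc3)C2=O)c1` returns only a limit of the assay in this assay, namely > 100000 nM. That limit is recorded as the limit of > 100000 nM in this assay, at which 1 of the 2 values shown sits. Compound 2 therefore has no number of its own and stands at the weak end of the two values shown, with compound 1 also sitting close to that limit.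

Compound 3 `COc1ccc(OC)c(NC(=O)c2cccc(/C=C3\CC(=O)N(c4ccccc4)C3=O)c2)c1` is not yet measured. It differs from compound 2 by 2,5-dimethoxyphenyl in place of 4-(difluoromethoxy)phenyl on an amide-type nitrogen. Within the data shown here, no measured pair covers this change, so nothing gives it a direction. Both measured compounds lie at or near the limit, and the expected step of a number no higher from compound 2 to compound 3 (the limit leaves the size open) is none beyond the scatter. Compound 3 is estimated at 100000 nM in this assay, within 40000 nM to 250000 nM, with a real chance that only a limit is reported again.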

Compound 3, half-maximal inhibitory concentration: > 100000 nM
Compound 3: no number, only a limit (the forecaster's own chance of this, stated with the estimate: 55%); the middle value lies on the limit itself.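

Compound 2 and compound 3 both return only a limit in this assay, so no step can be read between them: the limit of > 100000 nM in this assay, at which 2 of the 3 values shown sit. The compounds shown leave open whether any aryl group on the amide-type nitrogen changes the read-out in this assay beyond the scatter.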